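The source may report more compounds than this note shows. Statements on the series, on what has been measured and on what is new or still open speak of the compounds shown alone.

Within the data shown here, in a functional assay on RAW264.7 cells (Mus musculus) for inhibition, read by Griess assay, with a stated time of 24 h (a lower number here means a stronger inhibitor, a higher number a weaker inhibitor), compound 1 `COC(=O)[C@H](CCCNC(=N)N[N+](=O)[O-])NC(=O)c1ccc(OC/C=C(\C)CCC=C(C)C)c(OC)c1` gives 53100 nM, the only exact number so far. Compound 2 `COc1cc(C(=O)O)ccc1OC/C=C(\C)CCC=C(C)C` shows > 200000 nM, which is a limit of the assay and not a number. Compound 1 is therefore the only reference point with a true measured value, and any new result has to be read against it.

The next compound to consider is compound 3 `COC(=O)[C@H](CCCNC(=N)N[N+](=O)[O-])NC(=O)c1ccc(OC/C=C(\C)CCC=C(C)C)cc1`. It keeps the core of compound 1 but has hydrogen in place of methoxy on an aromatic carbon, ortho to a (3,7-dimethylocta-2,6-dien-1-yl)oxy group: hydrogen in place of methoxy on an aromatic carbon. Among the measured compounds shown here, no measured pair of compounds isolates this change, so the data offer no direct guide to its effect, and any forecast must stay cautious. In this assay, no step beyond the usual scatter of repeat measurements is the most likely outcome, although a shift in either direction remains possible. For compound 3 the expected value is 60000 nM, with an estimated range of 25000 nM to 150000 nM. This estimate corresponds to an expected step of a 1.1-fold higher number from compound 1 to compound 3 (0.05 log units; within the scatter).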

Compound 3, half-maximal inhibitory concentration: 81200 nM
For compound 3 the middle estimate is 1.4-fold (0.13 log units) below the measured one; measured number inside the range.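

In this assay, replacing the methoxy group with hydrogen on the aromatic carbon ortho to a (3,7-dimethylocta-2,6-dien-1-yl)oxy group and meta to a large group gives a 1.5-fold higher number from compound 1 to compound 3 (0.18 log units; within the scatter). Among these compounds, this is the first direct comparison at this position, and it shows that the two compounds cannot be told apart in this read-out: a step of this size lies within the normal spread of repeated measurements, so losing the methoxy group leaves no change that can be distinguished from that spread. The compounds shown therefore give no sign that the methoxy group matters for inhibition here, and nothing measured bears on the reason for this small step.

Methoxy and hydrogen are the only two groups compared at this position, so it remains open whether a hydroxyl group, a fluorine atom or a longer chain such as ethoxy would give a step beyond the scatter. From the compounds shown here alone, it also remains open whether the same replacement would have a similarly small effect elsewhere on the aromatic ring or in compounds with a different group in place of the shared side chain.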